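The compounds below may be only part of what the source reports. "The series", "measured", "known", "first", "only" and "open" are said of these compounds alone.

Measured compounds:
compound 1 `Nc1nc(-c2ccco2)nc2sc(CN3CCC(F)CC3)cc12`, 740 nM
compound 2 `CCc1ccc(-c2nc(N)c3cc(CN4[C@H](C)CCC[C@@H]4C)sc3n2)o1`, 190 nM
compound 3 `C[C@@H]1CCC[C@H](C)N1Cc1cc2c(N)nc(-c3ccc(C(F)F)o3)nc2s1`, 730 nM

Among the measured compounds shown here, in an assay on CHO-K1 cells for antagonist activity at adenosine receptor A1 (Homo sapiens), read by a beta-galactosidase reporter, with stated times of 15 min and 6 h (a higher number here means a weaker inhibitor, a lower number a stronger inhibitor), compound 3 gives 730 nM, the second highest of the three numbers; it sits within the scatter of compound 1, and the only step that reaches it, a 3.8-fold higher number from compound 2 to compound 3 (0.58 log units; beyond the scatter), lies beyond the scatter.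

Compound 4 `Nc1nc(-c2ccc(C(F)F)o2)nc2sc(CN3CCC(F)CC3)cc12` differs from compound 3 in one place: 4-fluoropiperidin-1-yl in place of 2,6-dimethylpiperidin-1-yl on a saturated chain carbon bound to an aromatic carbon. For the measured compounds named here, no measured step isolates this change. Going by the values given here, compound 1 carries the same 4-fluoropiperidin-1-yl group but also lacks the difluoromethyl on the furan, so it differs from compound 3 in two places, and the two values show only that compound 1 and compound 3 are within the scatter of each other. Among the compounds with values here, the single measured step, a 3.8-fold higher number from compound 2 to compound 3 (0.58 log units; beyond the scatter), concerns the furan substituent and does not bear on the amine exchange.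

Within the data shown here, with no direct precedent, the expected step of a 1.4-fold higher number from compound 3 to compound 4 (0.14 log units; within the scatter) is small and uncertain in direction. Compound 4 is therefore estimated at 1000 nM, with a likely range of 300 nM to 3500 nM in this assay.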

Compound 4, inhibition constant: 1670 nM
Estimate against measurement, compound 4: 1.7-fold (0.22 log units) below; the range from low to high includes it.
By their numbers in this assay, from the lowest: compound 2; then compounds 3 and 1 (each within the scatter of the next); then compound 4.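

In this assay, the amine on the saturated chain carbon bound to an aromatic carbon now has a step of its own: 4-fluoropiperidin-1-yl in place of 2,6-dimethylpiperidin-1-yl gives a 2.3-fold higher number from compound 3 to compound 4 (0.36 log units; beyond the scatter). The difluoromethyl group is also now set against hydrogen on an aromatic carbon, with the 4-fluoropiperidin-1-yl group held constant, and this gives a 2.3-fold higher number from compound 1 to compound 4 (0.35 log units; beyond the scatter), the same direction as a 3.8-fold higher number from compound 2 to compound 3 (0.58 log units; beyond the scatter), where it replaces ethyl with 2,6-dimethylpiperidin-1-yl held constant. No measured evidence is available to explain either new step.

The compounds shown leave open whether the amine step keeps its size and direction with ethyl or hydrogen on that aromatic carbon. They also leave open how morpholine or unsubstituted piperidine would stand at the amine place, and how trifluoromethyl would compare with difluoromethyl.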